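This account rests on a few compounds, and the source may have more. Where it says the series, first, only, none or still open, it means among the compounds named here.

Of the compounds shown here, three have so far been measured in a functional assay on 786-0 cells (Homo sapiens) for inhibition, read by sulforhodamine B assay, with a stated time of 48 h; a lower number here means a stronger inhibitor of growth, a higher number a weaker inhibitor of growth. Compound 1 `COc1cc(/C=C/C2CC(=O)C=CO2)cc(OC)c1OC` gives 125 uM. Compound 3 `COc1cc(/C=C/C2CC=CC(=O)N2)cc(OC)c1` gives 173 uM in this assay, and the values of compound 3 and compound 1 lie within the usual scatter of one another, so neither can be called the stronger inhibitor of growth. Compound 2 `COc1ccc(/C=C/C2CC=CC(=O)N2)cc1OC` reaches only the limit of the assay, > 964 uM, which is a limit and not a number (the limit of > 964 uM in this assay, at which 1 of the 3 values shown sits).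

Compound 4 `COc1cc(/C=C/C2CC=CC(=O)N2)cc(OC)c1OC` has not been measured. It differs from compound 3 in one place: methoxy in place of hydrogen on an aromatic carbon. With this added methoxy, compound 4 carries the same three-methoxy arrangement that compound 1 carries, while the rest of compound 3 is kept unchanged. Compound 1 and compound 3 differ in more than this methoxy, yet their values in this assay sit within the scatter of each other, so no shift tied to the extra methoxy can be read from them. No change beyond the scatter is therefore expected in this assay when the methoxy enters. The expected step is a 1.2-fold lower number from compound 3 to compound 4 (0.09 log units; within the scatter), no larger than the scatter. Compound 4 is estimated at 140 uM, with a range from 45 uM to 450 uM.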

Compound 4, concentration for growth inhibition (reported as GI): > 864 uM
Compound 4: a limit, no number (the forecaster's own chance of this, stated with the estimate: 15%); middle value at least 6.1-fold (0.79 log units) from the limit.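

In this assay, going by these compounds alone, methoxy in place of hydrogen on this aromatic carbon, ortho to two methoxy groups and para to a group of 9 heavy atoms, is not a silent change: it gives an at least 4.9-fold higher number from compound 3 to compound 4 (0.69 log units; beyond the scatter), so this position responds to substitution in a way the earlier compounds could not reveal. Compound 4 gives no number, only a limit of the assay: the limit of > 864 uM in this assay, at which 1 of the 4 values shown sits.

With the three methoxy groups kept, exchanging the group of 7 heavy atoms that holds two oxygens for the one that holds a nitrogen and an oxygen gives an at least 6.9-fold higher number from compound 1 to compound 4 (0.83 log units; beyond the scatter), so in this pair the three-methoxy arrangement alone does not preserve the growth inhibition of compound 1.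

The step between compound 2 and compound 4 cannot be read, as both values are limits. As far as these compounds go, it remains open how far compound 4 really lies from compound 3, and whether a hydroxyl, an ethoxy or a fluorine on the same aromatic carbon would behave like the methoxy or like the hydrogen it replaces.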